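A few compounds are considered here, and "the series" means these few. Any claim that something is new, unique, unknown or untested is made for them only; others in the source may bear on it.

Of the compounds shown here, three measured so far share one core and differ only in the group on the aromatic carbon of a six-membered aromatic ring of carbon only. Compound 1 `CC(=O)OC[C@H]1O[C@H](OC[C@@H](Cn2cc(CN(c3nc(-c4ccc(Cl)cc4)no3)C3CCCCC3)nn2)OC(C)=O)C=C[C@@H]1OC(C)=O` gives 35.5 ug/mL in an ADME assay on RAW264.7 cells (Mus musculus) for cytotoxicity, read by MTT assay, with a stated time of 48 h; a higher number here means that more compound is tolerated, a lower number that less compound is tolerated. Compound 2 `CC(=O)OC[C@H]1O[C@H](OC[C@@H](Cn2cc(CN(c3nc(-c4ccc(C(F)(F)F)cc4)no3)C3CCCCC3)nn2)OC(C)=O)C=C[C@@H]1OC(C)=O` gives 64.1 ug/mL in this assay, and compound 3 `CC(=O)OC[C@H]1O[C@H](OC[C@@H](Cn2cc(CN(c3nc(-c4ccc(Br)cc4)no3)C3CCCCC3)nn2)OC(C)=O)C=C[C@@H]1OC(C)=O` gives 39.1 ug/mL in this assay. The three numbers lie close together: a 1.8-fold higher number from compound 1 to compound 2 (0.26 log units; within the scatter), a 1.1-fold higher number from compound 1 to compound 3 (0.04 log units; within the scatter) and a 1.6-fold lower number from compound 2 to compound 3 (0.21 log units; within the scatter). Compound 3 thus stands second highest of the three numbers, with compound 1 nearest to it and compound 2 furthest from it, both within the scatter.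

Compound 4 `CC(=O)OC[C@H]1O[C@H](OC[C@@H](Cn2cc(CN(c3nc(-c4ccc([N+](=O)[O-])cc4)no3)C3CCCCC3)nn2)OC(C)=O)C=C[C@@H]1OC(C)=O` has not yet been measured. Its change from compound 3 is nitro in place of bromo on an aromatic carbon. Going by the values given here, no measured step exchanges bromo for nitro, so the steps that bear on this one are the three exchanges of a single group at the same place among compounds 1, 2 and 3, each of which stayed within the scatter. The expectation is therefore no step beyond the scatter from compound 3 to compound 4, that is a 1.0-fold higher number from compound 3 to compound 4 (0.01 log units; within the scatter) in this assay. Compound 4 is estimated at 40 ug/mL in this assay, with a range from 20 ug/mL to 80 ug/mL.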

Compound 4, half-maximal cytotoxic concentration: 64.1 ug/mL
The estimate for compound 4 lay 1.6-fold (0.20 log units) below the measured number, and the stated range covers the measured number.
By their numbers in this assay, from the lowest: compounds 1, 3, 2 and 4 (each within the scatter of the next).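

In this assay the exchange at this place now extends beyond halogen and trifluoromethyl: nitro brings three heavy atoms and two hydrogen-bond acceptors where bromo has one heavy atom and no acceptor, and the result is a 1.6-fold higher number from compound 3 to compound 4 (0.21 log units; within the scatter) together with a 1.8-fold higher number from compound 1 to compound 4 (0.26 log units; within the scatter) and no change at the digits printed from compound 2 to compound 4 (within the scatter) in the same series. The earlier compounds had shown this flat picture only for chloro, bromo and trifluoromethyl, whereas compounds 1, 2, 3 and 4 now show that an aromatic carbon para to a large group also accepts a group with hydrogen-bond acceptors and no step leaves the scatter. Nothing given here explains these numbers or tells why compound 2 and compound 4 print the same value.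

The compounds shown leave open whether a group of another kind on this carbon, such as an amine, a carboxylic acid or a longer alkyl chain, would also stay within the scatter. They also leave open whether the same exchanges would stay within it on a different core or at another place on the ring.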